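From compound 2 to compound 3: one group exchanged

The compounds below may be only part of what the source reports. "The series", "measured", "known", "first", "only" and "open" are said of these compounds alone.

compound 1 (`Cc1cc(C(=O)O)ccc1OCCCCOc1ccc(C(=O)CC(C)C)c(O)c1C`): 100%
compound 2 (`Cc1c(OCCCCOCOc2ccc(C(=O)O)cc2)ccc(C(=O)CC2CCCC2)c1O`): 100%

In an ADME assay on a cell-free system (plasma, Rattus norvegicus) for metabolic stability, read by LC-MS, with a stated time of 60 min, tested at 100 uM (a higher number here means that more of the compound is left, a lower number that less of the compound is left), compound 2 stands level with compound 1, and the two values lie within the usual scatter of each other. Compound 3 (`Cc1c(OCCCCOc2ccc(C(=O)O)cc2F)ccc(C(=O)CC2CCCC2)c1O`) has not been measured yet. It differs from compound 2 in one place: 4-carboxy-2-fluorophenyl stands in place of (4-carboxyphenoxy)methyl on an oxygen on a saturated carbon (4-carboxy-2-fluorophenyl in place of (4-carboxyphenoxy)methyl on an oxygen on a saturated carbon). Going by the values given here, no two measured compounds differ in one place only, so no measured step can serve as a guide. Among the compounds with values here, the only guide is the pair of values, with compound 1 at 100% and compound 2 at 100%. On that basis, no step beyond the scatter is expected in this assay. The estimated step is a number 2 percentage points lower from compound 2 to compound 3 (within the scatter). For compound 3 the estimated value is 98%, with an expected range of 86% to 105%.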

Compound 3, percent of the compound remaining: 97%
For compound 3 the middle estimate is 1 percentage points above the measured one, and the stated range covers the measured number.
By their numbers in this assay, from the lowest: compounds 3, 1 and 2 (each within the scatter of the next).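

Going by these compounds alone, the exchange of (4-carboxyphenoxy)methyl for 4-carboxy-2-fluorophenyl, on an oxygen on a saturated carbon, gives the first step that can be read between two compounds differing in one place: in this assay it is a number 3 percentage points lower from compound 2 to compound 3 (within the scatter), so this group exchange leaves the read-out within the usual scatter. The entering group carries a fluorine that the leaving group lacks, and its presence comes with no step beyond that scatter in this assay. Nothing measured here explains this result.

As this is a single exchange that alters both the fluorine and the link to the ring, the compounds shown cannot separate what each part contributes. Also open, as far as these compounds go, is whether a methyl ester in place of the carboxylic acid would stay level in this assay or give a step beyond the scatter.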